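A few compounds are considered here, and "the series" means these few. Any claim that something is new, unique, unknown or untested is made for them only; others in the source may bear on it.

Compound 1, `CCCc1n[nH]c2c(=O)n(NC(=O)c3ccncc3)c(-c3cccc(OC)c3)nc12`: 11.4%
Compound 2, `O=C(Nn1c(-c2cccc([N+](=O)[O-])c2)nc2c(-c3ccc(F)cc3)n[nH]c2c1=O)c1cccnc1`: 24.5%

Both values come from a functional assay on SK-MEL-2 cells (Homo sapiens) for cytotoxicity, read by sulforhodamine B assay, with a stated time of 2 days, tested at 100 uM; a higher number here means more inhibition at the concentration tested (going by the name of the read-out), a lower number less inhibition. Compound 2 stands highest of the two numbers; the nearest, compound 1, lies lower by a margin beyond the usual scatter. Compound 3, `O=C(Nn1c(-c2cccc([N+](=O)[O-])c2)nc2c(-c3cccs3)n[nH]c2c1=O)c1cccnc1`, is not yet measured. It differs from compound 2 in one place: thiophen-2-yl in place of 4-fluorophenyl on an aromatic carbon. Within the data shown here, no pair of measured compounds differs in one place, so nothing yet shows how such a swap moves the read-out. The step of a number 3.5 percentage points lower from compound 2 to compound 3 (within the scatter) is therefore expected to stay within the scatter, with no clear direction. Compound 3 is estimated at 21%, with a range from 6% to 38%.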

Compound 3, a percentage reported as inhibition, at one concentration (the size of the read-out at that concentration, not a potency): 3.26%
Estimate against measurement, compound 3: 17.7 percentage points above; the measured number lies below the stated range.
By their numbers in this assay, from the lowest: compounds 3 and 1 (each within the scatter of the next); then compound 2.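

Among these compounds, the first comparison that changes only one place shows that the group on this aromatic carbon matters: in this assay, putting thiophen-2-yl in place of 4-fluorophenyl gives a number 21.2 percentage points lower from compound 2 to compound 3 (beyond the scatter). So, with the rest of the molecule held fixed, the read-out is sensitive to which aromatic ring sits here. No measurement available here accounts for this drop.

As far as these compounds go, how an amine or a carboxylic acid on this carbon would read remains open. So does whether the same swap would act alike on a compound carrying the other groups of compound 1.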